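The compounds below may be only part of what the source reports. "The series", "measured", "known", "first", "only" and "open" are said of these compounds alone.

Compound 1 `COc1ccc(-c2cn3ccnc3c(-c3ccc4ncn(C5CCCCC5)c4c3)n2)cc1` is the starting point here. Going by the values given here, in a functional assay on MOLT-4 cells (Homo sapiens) for inhibition, read by sulforhodamine B assay, with a stated time of 48 h, tested at 10 uM (on this read-out higher numbers stand for more inhibition at the one concentration tested (going by the name of the read-out) and lower numbers for less inhibition), compound 1 gives 82.8%, which is the higher of the two numbers measured so far; its only neighbour is compound 2 `c1csc(-c2cn3ccnc3c(-c3ccc4ncn(C5CCCCC5)c4c3)n2)c1`, which in this assay gives 30.8%. Among the compounds with values here, the one measured step, thiophen-2-yl in place of 4-methoxyphenyl on an aromatic carbon, brought a number 52 percentage points lower from compound 1 to compound 2 (beyond the scatter).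

Compound 3 `FC(F)(F)c1cccc(-c2cn3ccnc3c(-c3ccc4ncn(C5CCCCC5)c4c3)n2)c1` carries a different group at the same place:

3-(trifluoromethyl)phenyl in place of 4-methoxyphenyl on an aromatic carbon

The step to compound 3 has a bearing from the step from compound 1 to compound 2: both remove the 4-methoxyphenyl, with its single hydrogen-bond acceptor, from the same aromatic carbon, and that earlier removal produced a large loss. The entering group in compound 3 is a six-membered ring of carbon only, as in compound 1, with no hydrogen-bond acceptor, so the expected step in this assay is a fall, though smaller than the measured one because that measured step was a number 52 percentage points lower from compound 1 to compound 2 (beyond the scatter) and involved a different ring. For compound 3 the estimate is therefore 50%, expected to lie between 20% and 80%, a step of a number 32.8 percentage points lower from compound 1 to compound 3 (beyond the scatter).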

Compound 3, a percentage reported as inhibition, at one concentration (the size of the read-out at that concentration, not a potency): 32.9%
The estimate for compound 3 lay 17.1 percentage points above the measured number; the range from low to high includes it.
By their numbers in this assay, from the lowest: compounds 2 and 3 (each within the scatter of the next); then compound 1.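

The fall is not peculiar to thiophen-2-yl: in this assay, 3-(trifluoromethyl)phenyl keeps the six-membered aromatic ring of carbon only found in compound 1, yet the change gives a number 49.9 percentage points lower from compound 1 to compound 3 (beyond the scatter). So keeping that ring type is not enough at this position to retain the number seen with 4-methoxyphenyl, and the two replacements cannot be told apart, with a number 2.1 percentage points higher from compound 2 to compound 3 (within the scatter), even though they differ in ring and in size. Of the three groups shown, only 4-methoxyphenyl gives a high number, and no measurement on hand explains why.

Compound 3 differs from compound 1 in both the substituent and its place on the phenyl ring, so the shown compounds leave open whether the methoxy group, its place or both matter. Comparing 3-methoxyphenyl, 4-(trifluoromethyl)phenyl and unsubstituted phenyl at this same aromatic carbon would separate these possibilities, and 4-aminophenyl would show whether another group in that place can match the methoxy group.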